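Tert-butyl on the amine: compound 3 to compound 4

The source may report more compounds than this note shows. Statements on the series, on what has been measured and on what is new or still open speak of the compounds shown alone.

In an in vitro ADME assay on microsomes from liver (Homo sapiens) for pharmacokinetics (on this read-out lower numbers stand for slow clearance and higher numbers for fast clearance), compound 3 `CCN1CC[C@H](NC(=O)C[C@@H]2C(=O)NC=CN2S(=O)(=O)c2ccc(C)cc2)C(C)(C)C1` gives < 50 mL.min-1.g-1 as a limit, not a number. Compound 1 `Cc1ccc(S(=O)(=O)N2C=CNC(=O)[C@H]2CC(=O)N[C@@H]2CCCc3ccccc32)cc1` gives 514 mL.min-1.g-1 here and compound 2 `Cc1ccc(S(=O)(=O)N2C=CNC(=O)[C@H]2CC(=O)NC2CCCCC2)cc1` gives 147 mL.min-1.g-1 here. Among the measured compounds shown here, compound 4 `Cc1ccc(S(=O)(=O)N2C=CNC(=O)[C@H]2CC(=O)N[C@H]2CCN(CC(C)(C)C)CC2(C)C)cc1` carries tert-butyl in place of methyl on a saturated chain carbon bound to an amine nitrogen in a ring as its only change. The measured steps that bear on this all sit on an amide-type nitrogen, so they guide only loosely: an at least 10-fold lower number from compound 1 to compound 3 (1.01 log units; beyond the scatter) and an at least 2.9-fold lower number from compound 2 to compound 3 (0.46 log units; beyond the scatter) came with the amine-bearing group, and a 3.5-fold lower number from compound 1 to compound 2 (0.54 log units; beyond the scatter) came with a smaller carbon-only group. In this assay a modest rise is therefore expected, estimated as an at least 1.8-fold higher number from compound 3 to compound 4 (0.25 log units; that floor lies within the scatter) for this change. Compound 4 is estimated at 90 mL.min-1.g-1 with an expected range of 40 mL.min-1.g-1 to 220 mL.min-1.g-1 for the measurement.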

Compound 4, intrinsic clearance in microsomes: 405 mL.min-1.g-1
Compound 4: the middle estimate sits 4.5-fold (0.65 log units) below what was measured; measured number above the stated range.
By their numbers in this assay, from the lowest: compound 2; then compounds 4 and 1 (each within the scatter of the next). At a limit, below all of these: compound 3.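

In this assay tert-butyl in place of methyl on a saturated chain carbon bound to an amine nitrogen in a ring gives an at least 8.1-fold higher number from compound 3 to compound 4 (0.90 log units; beyond the scatter) with the rest of the molecule unchanged. The amine-bearing group therefore does not by itself keep the number low: compound 4 at 405 mL.min-1.g-1 and compound 1 at 514 mL.min-1.g-1 lie within the scatter of each other. The step has only a floor, since compound 3 stands at a limit and not a number: the limit of < 50 mL.min-1.g-1 in this assay, at which 1 of the 4 values shown sits.

Open, on these data alone, is where on the way from ethyl to neopentyl the number climbs. Also open, as far as these compounds go, is whether isobutyl or a chain ending in a carboxylic acid at this place would behave like ethyl or like neopentyl.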